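Swapping the Pyridine on the Triazole for Bromophenyl

The source may report more compounds than this note shows. Statements on the series, on what has been measured and on what is new or still open speak of the compounds shown alone.

The set comprises three measured compounds and one awaiting measurement, all tested in a functional assay on A549 cells (Homo sapiens) for cytotoxicity, read by MTT assay, with a stated time of 4 days; on this read-out lower numbers stand for stronger inhibition and higher numbers for weaker inhibition. Compound 1 `C=C1C[C@]23C[C@@]1(O)CC[C@H]2c1ccc(O)c(C)c1[C@@H]3Cn1cc(-c2ccccn2)nn1` reaches only a limit of the assay, > 20000 nM. Compound 3 `Cc1ccc(S(=O)(=O)Oc2ccc3c(c2C)[C@H](Cn2cc(-c4ccccc4)nn2)[C@@]24CC(=O)[C@@](C)(CC[C@@H]32)C4)cc1` likewise gives a limit, > 20000 nM. Within the data shown here, compound 2 `C=C1C(=O)[C@]23C[C@@]1(O)CC[C@H]2c1ccc(OS(=O)(=O)c2ccc(C)cc2)c(C)c1[C@@H]3Cn1cc(-c2ccccn2)nn1` is the one member with a numerical result, and in this assay compound 2 gives 2310 nM. Among the measured compounds shown here, compound 2 therefore stands alone among the numbers, since the limit of > 20000 nM in this assay, at which 2 of the 3 values shown sit, is where the other two compounds sit, so no measured step exists against which to calibrate the change that follows.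

Compound 4 `C=C1C(=O)[C@]23C[C@@]1(O)CC[C@H]2c1ccc(OS(=O)(=O)c2ccc(C)cc2)c(C)c1[C@@H]3Cn1cc(-c2ccc(Br)cc2)nn1` is built from compound 2 by one alteration: 4-bromophenyl in place of pyridin-2-yl on an aromatic carbon. For the measured compounds named here, the data hold no measured pair that isolates this exchange, so the expectation rests on compound 2 alone. The estimated step of a 1.3-fold higher number from compound 2 to compound 4 (0.11 log units; within the scatter) is expected to be small, in no clear direction and within the usual scatter, with some chance that compound 4 returns only a limit. Compound 4 is therefore expected to give 3000 nM, with a range from 800 nM to 15000 nM.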

Compound 4, half-maximal inhibitory concentration: 1630 nM
Estimate against measurement, compound 4: 1.8-fold (0.26 log units) above; the range from low to high includes it.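

In this assay, among these compounds, the first measured pair at this position gives a 1.4-fold lower number from compound 2 to compound 4 (0.15 log units; within the scatter), so the exchange of pyridin-2-yl for 4-bromophenyl on an aromatic carbon of the five-membered aromatic ring with 3 nitrogen can now be read directly. In this pair, removing the ring nitrogen of the pyridine, with the hydrogen-bond acceptor counted there, and adding a bromine-bearing ring of carbon only does not move the read-out beyond the scatter, so the numerical result does not depend on that acceptor on this core. Compound 4 also gives a number and not a limit, which places it with compound 2 and apart from the other mark in the set: the limit of > 20000 nM in this assay, at which 2 of the 4 values shown sit.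

The compounds shown leave open whether this tolerance extends to other groups at the same place, such as an unsubstituted phenyl, a phenyl ring bearing a carboxylic acid or an amine, or a longer alkyl chain such as n-butyl. This single pair also leaves open whether the same exchange would behave the same way on a core lacking the tosylate or the other features of compound 2.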